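The source may hold more compounds than are shown below. What is called first, only, known or untested is meant among the compounds shown, and "the series" means these compounds.

Measured compounds in a functional assay on A549 cells (Homo sapiens) for antiproliferative activity; on this read-out lower numbers stand for an effect already at smaller amounts and higher numbers for an effect only at larger amounts of compound:
- compound 1 `CCCCCCCCCCCCO/N=C(\CCCCCC)c1cc(OC)c2c(c1OC)C(=O)C=CC2=O`: > 10 ug/mL
- compound 2 `CCCCCCCCCCCCO/N=C/c1cc(OC)c2c(c1OC)C(=O)C=CC2=O`: > 10 ug/mL

Where compound 1 stands: its only value is a limit of this assay, not a number, compound 1 giving > 10 ug/mL. Compound 2 also reaches only the limit, > 10 ug/mL. The whole picture of this assay is therefore the single line (the limit of > 10 ug/mL in this assay, at which 2 of the 2 values shown sit), so no size or direction of any step between measured compounds can be read from it.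

Compound 3 `CCCCCCCO/N=C(\CCCCCC)c1cc(OC)c2c(c1OC)C(=O)C=CC2=O` is the next member to be run in this assay. Against compound 1 the change is hydrogen in place of pentyl on a saturated chain carbon, seven bonds along the chain from an oxygen on an unsaturated carbon. Among the measured compounds shown here, no measured pair shows such a shortening of the chain at the oxygen on the unsaturated carbon, so nothing here fixes a step for it. Given that compound 1 stands at > 10 ug/mL, the step to compound 3 is expected to be none beyond the scatter, that is a step that the limit leaves unreadable from compound 1 to compound 3. Compound 3 is accordingly estimated at 15 ug/mL, within a range of 5 ug/mL to 50 ug/mL, most likely reported once more as a limit rather than a number.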

Compound 3, concentration for half-maximal effect: > 10 ug/mL
Compound 3: no number, only a limit; the forecaster's own chance of this, stated with the estimate: 75%; the middle value is on the limit's open side.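

No step can be read from compound 1 to compound 3, since in this assay both compounds reach only a limit of the assay: the limit of > 10 ug/mL in this assay, at which 3 of the 3 values shown sit.

The compounds shown leave open whether any change to the chains on the shared core gives a number on this read-out, and in which direction such a change would act.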